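The source may hold more compounds than are shown below. What is called first, only, known or untested is meant among the compounds shown, and "the series" means these compounds.

The compounds here share one core and differ only in the group attached to a carbonyl carbon at one end. Compound 1 `O=C(Nc1ccc2nc(NC(=O)C3CCCCC3)sc2c1)c1ccccc1F` carries a 2-fluorophenyl there, and in a functional assay on WI-38 VA13 cells (Homo sapiens) for cytotoxicity (a lower number here means that less compound is needed, a higher number that more compound is needed for the effect), compound 1 gives 0.14 ug/mL. Compound 2 `COc1ccc(C(=O)Nc2ccc3nc(NC(=O)C4CCCCC4)sc3c2)cc1` gives 4.9 ug/mL, and compound 3 `O=C(Nc1ccc2nc(NC(=O)C3CCCCC3)sc2c1)c1c(Cl)cccc1Cl` gives 0.015 ug/mL. Among these three numbers compound 1 stands second highest: it lies nearer to compound 3, with a 9.3-fold lower number from compound 1 to compound 3 (0.97 log units; beyond the scatter), than to compound 2, with a 35-fold higher number from compound 1 to compound 2 (1.54 log units; beyond the scatter). Both steps change only the aromatic group on the carbonyl carbon, and both move the number well beyond the scatter, so this group clearly matters for the outcome.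

Compound 4 `CC(=O)Nc1ccc2nc(NC(=O)C3CCCCC3)sc2c1` goes further: methyl in place of 2-fluorophenyl on a carbonyl carbon. Going by the values given here, no measured step removes the ring altogether, so the two aryl swaps are the only guide. They show that even a change of substituents on this ring shifts the number by a large amount in either direction, and losing the ring entirely is a bigger structural change than either of them. A sizeable step upward in this assay is therefore expected for compound 4, whose estimated value is 5 ug/mL, with a likely range from 0.5 ug/mL to 50 ug/mL. This expectation corresponds to a step of a 36-fold higher number from compound 1 to compound 4 (1.55 log units; beyond the scatter).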

Compound 4, half-maximal effective concentration: 2.7 ug/mL
Beside the measured number, compound 4's estimate is 1.9-fold (0.27 log units) above it, within the range that was stated.
By their numbers in this assay, from the lowest: compound 3; then compound 1; then compounds 4 and 2 (each within the scatter of the next).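

In this assay putting methyl on the carbonyl carbon gives a 19-fold higher number from compound 1 to compound 4 (1.29 log units; beyond the scatter) and a 180-fold higher number from compound 3 to compound 4 (2.26 log units; beyond the scatter) for the two compounds with the lowest numbers, so their low numbers do not carry over once the 2-fluorophenyl or 2,6-dichlorophenyl group is gone. Having an aromatic ring in this place is still not enough for a low number: 4-methoxyphenyl has one, yet a 1.8-fold lower number from compound 2 to compound 4 (0.26 log units; within the scatter) leaves no real separation from methyl, so among these compounds what counts is which aromatic group sits on the carbonyl carbon, not merely whether one does. Nothing here explains why these groups differ so widely.

The compounds shown leave open whether a saturated ring such as cyclohexyl or a longer chain such as butyl in this place would give a number like that of methyl or like those of the two halogen-bearing rings. Going by these compounds, all four compounds also share the rest of their structure, so how a change elsewhere would act on the number remains unknown.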